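A Methyl on the Furan: From Compound 3 to Compound 4

A few compounds are considered here, and "the series" means these few. Any claim that something is new, unique, unknown or untested is made for them only; others in the source may bear on it.

Three compounds were measured in an assay on membranes from brain (strain Sprague-Dawley) for displacement of a labelled ligand from adenosine receptor A1 (Rattus norvegicus), read by scintillation counting, with a stated time of 1 h; on this read-out lower numbers stand for stronger inhibition and higher numbers for weaker inhibition:
compound 1, `Nc1nc(-c2cccc(Cl)c2)cc(-c2ccco2)n1`, 39.1 nM;
compound 2, `Cc1ccc(-c2cc(-c3cccc(Cl)c3)nc(N)n2)o1`, 129 nM;
compound 3, `COc1cccc(-c2cc(-c3ccco3)nc(N)n2)c1`, 61.4 nM.

Among these, compound 3 has the second highest number of three; compound 1 is its nearest neighbour, within the scatter, while compound 2 lies beyond the scatter above it. Compound 4, `COc1cccc(-c2cc(-c3ccc(C)o3)nc(N)n2)c1`, differs from compound 3 by methyl in place of hydrogen on an aromatic carbon. The same change is already on record: a 3.3-fold higher number from compound 1 to compound 2 (0.52 log units; beyond the scatter). The other step, a 1.6-fold higher number from compound 1 to compound 3 (0.20 log units; within the scatter), suggests the methoxy-bearing core behaves much like the chloro-bearing one. The methyl step is therefore expected to carry over, giving an expected 3.1-fold higher number from compound 3 to compound 4 (0.49 log units; beyond the scatter). Compound 4 is estimated at 190 nM, with a range from 80 nM to 450 nM.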

Compound 4, inhibition constant: 145 nM
For compound 4 the middle estimate is 1.3-fold (0.12 log units) above the measured one; low and high end bracket the measured number.
By their numbers in this assay, from the lowest: compounds 1 and 3 (each within the scatter of the next); then compounds 2 and 4 (each within the scatter of the next).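

In this assay the change from furan-2-yl to 5-methylfuran-2-yl also gives a higher number on the methoxy-bearing core (a 2.4-fold higher number from compound 3 to compound 4 (0.37 log units; beyond the scatter)), so the step at this carbon next to the ring oxygen is now seen on two cores, and the two agree: the same change on two cores in this assay, a 3.3-fold higher number (0.52 log units; beyond the scatter) from compound 1 to compound 2 and a 2.4-fold higher number (0.37 log units; beyond the scatter) from compound 3 to compound 4, 1.4-fold (0.15 log units) apart, within the scatter of two such steps. Methoxy in place of chloro stays within the scatter with the methyl present (a 1.1-fold higher number from compound 2 to compound 4 (0.05 log units; within the scatter)), as it did without the methyl: the same change on two cores in this assay, a 1.6-fold higher number (0.20 log units; within the scatter) from compound 1 to compound 3 and a 1.1-fold higher number (0.05 log units; within the scatter) from compound 2 to compound 4, 1.4-fold (0.15 log units) apart, within the scatter of two such steps.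

The compounds shown leave open whether a longer chain such as ethyl, or a hydroxymethyl group, at this furan carbon would move the number as methyl does. They also leave open whether the methyl step would hold with a nitrile in place of chloro or methoxy.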